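Replacing methoxymethoxy with fluoro: a small step expected

The compounds below may be only part of what the source reports. "The series", "measured", "known", "first", "only" and "open" are said of these compounds alone.

Measured in a functional assay on HL-60 cells (Homo sapiens) for cytotoxicity, read by WST assay, with a stated time of 48 h (on this read-out lower numbers stand for an effect already at smaller amounts and higher numbers for an effect only at larger amounts of compound), so far:
Compound 1 `O=C1OC[C@H](Cc2ccccc2)[C@H]1Cc1ccccc1Cl` gives 37000 nM 
Compound 2 `COc1cccc(C[C@H]2C(=O)OC[C@@H]2Cc2ccccc2)c1` gives 66000 nM 
Compound 3 `COCOc1cccc(C[C@H]2C(=O)OC[C@@H]2Cc2ccccc2)c1` gives 80000 nM 

In this assay compound 3 lies within the scatter of compound 2, and it has a higher number than compound 1, beyond the scatter. Compound 4 `O=C1OC[C@H](Cc2ccccc2)[C@H]1Cc1cccc(F)c1` has not yet been measured. It differs from compound 3 as follows: fluoro in place of methoxymethoxy on an aromatic carbon with fluoro in place of methoxymethoxy on an aromatic carbon. For the measured compounds named here, the only measured step at this group is a 1.2-fold higher number from compound 2 to compound 3 (0.08 log units; within the scatter) and it stays within the scatter. Going by the values given here, no measured compound carries fluoro, so this guidance is thin. Compound 1 with 37000 nM and compound 2 with 66000 nM also lack methoxymethoxy, and the estimate is therefore placed nearer to them. The expected move is a 1.6-fold lower number from compound 3 to compound 4 (0.20 log units; within the scatter) and no change beyond the scatter is anticipated. Compound 4 is estimated at 50000 nM with an expected range from 20000 nM to 110000 nM in this measurement.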

Compound 4, half-maximal effective concentration: 75000 nM
For compound 4 the middle estimate is 1.5-fold (0.18 log units) below the measured one; measured number inside the range.
By their numbers in this assay, from the lowest: compounds 1, 2, 4 and 3 (each within the scatter of the next, the first and the last beyond it).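

In this assay, fluoro in place of methoxymethoxy on this aromatic carbon leaves the number within the scatter (a 1.1-fold lower number from compound 3 to compound 4 (0.03 log units; within the scatter)). Fluoro in place of methoxy does the same (a 1.1-fold higher number from compound 2 to compound 4 (0.06 log units; within the scatter)), so fluoro, methoxy and methoxymethoxy at this place cannot be told apart in this measurement, although fluoro brings one heavy atom and no hydrogen-bond acceptors. Only 3-fluorophenyl in place of 2-chlorophenyl goes beyond the scatter, and modestly (a 2.0-fold higher number from compound 1 to compound 4 (0.31 log units; beyond the scatter)), but that change alters both the halogen and its place on the ring, so neither can be singled out.

No available evidence explains these results. As far as these compounds go, whether an amine or a carboxylic acid at this place would move the number beyond the scatter remains open.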